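Compound 4: a Naphthalen-2-yl Ester Variant of Compound 3

The compounds below may be only part of what the source reports. "The series", "measured", "known", "first", "only" and "open" are said of these compounds alone.

Compound 3 `CC1=NC(C)=C(C(=O)O)C(c2cccc(Cl)c2)/C1=C(\O)OC/C=C/c1ccc(C)cc1` gives 890 nM in a functional assay on IMR-32 cells for inhibition of Voltage-dependent N-type calcium channel subunit alpha-1B (Homo sapiens), read by calcium flux; a higher number here means a weaker inhibitor, a lower number a stronger inhibitor. Among the three measured compounds it stands second highest: compound 2 `CC1=NC(C)=C(C(=O)O)C(c2cccc(Br)c2)/C1=C(\O)OC/C=C/c1ccccc1` gives 790 nM, within the scatter of compound 3, while compound 1 `CC1=NC(C)=C(C(=O)O)C(c2cccc(C)c2)/C1=C(\O)OC/C=C/c1ccccc1` gives 1800 nM, the highest of the three. Among the measured compounds shown here, the only single-place step measured, a 2.3-fold lower number from compound 1 to compound 2 (0.36 log units; beyond the scatter), concerns the substituent on the aromatic ring and not the ester side chain. Compound 4 `CC1=NC(C)=C(C(=O)O)C(c2cccc(Cl)c2)/C1=C(\O)OCc1ccc2ccccc2c1` differs from compound 3 by naphthalen-2-yl in place of 2-(4-methylphenyl)ethenyl on a saturated chain carbon bound to an oxygen on an unsaturated carbon. For the measured compounds named here, no measured step bears on this change, so in this assay no step beyond the scatter is assumed, and the expected change is a 1.0-fold higher number from compound 3 to compound 4 (0.00 log units; within the scatter). Compound 4 is therefore estimated at 900 nM, with a range from 300 nM to 3000 nM that is kept wide for want of a guiding step.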

Compound 4, half-maximal inhibitory concentration: 1000 nM
The estimate for compound 4 lay 1.1-fold (0.05 log units) below the measured number; the range from low to high includes it.
By their numbers in this assay, from the lowest: compounds 2, 3, 4 and 1 (each within the scatter of the next, the first and the last beyond it).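

On a saturated chain carbon bound to an oxygen on an unsaturated carbon, naphthalen-2-yl in place of 2-(4-methylphenyl)ethenyl gives a 1.1-fold higher number from compound 3 to compound 4 (0.05 log units; within the scatter) in this assay. Between these two compounds, the double bond outside aromatic rings gives way to a second six-membered aromatic ring of carbon only, with no step beyond the scatter. No measurement at hand gives a cause for this result. Still open, from the compounds shown here alone, is whether a different kind of group at this place, such as a piperidine or a longer saturated carbon chain, would move the number beyond the scatter.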